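Bromo for chloro on a compound at the assay limit

The compounds below may be only part of what the source reports. "The series", "measured", "known", "first", "only" and "open" are said of these compounds alone.

Measured in a functional assay on MCF7 cells (Homo sapiens) for antiproliferative activity, read by MTT assay (a lower number here means a stronger inhibitor, a higher number a weaker inhibitor), where each value is a limit and not a number:
- compound 1 `NS(=O)(=O)c1cccc(/N=C2\NC(=O)/C(=C3/C(=O)Nc4ccc(Cl)cc43)S2)c1`: > 200000 nM
- compound 2 `NS(=O)(=O)c1cccc(/N=C2\NC(=O)/C(=C3/C(=O)N(Cc4ccccc4)c4ccccc43)S2)c1`: > 200000 nM
- compound 3 `CN1C(=O)/C(=C2\S/C(=N/c3ccc(S(N)(=O)=O)cc3)NC2=O)c2cc(Cl)ccc21`: > 200000 nM

Compound 1 gives no exact reading in this assay, only the limit > 200000 nM of the assay. It shares that position with the other two measured compounds, as the record shows: the limit of > 200000 nM in this assay, at which 3 of the 3 values shown sit. None of the three therefore has a number that could rank it against the others.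

Compound 4 `NS(=O)(=O)c1cccc(/N=C2\NC(=O)/C(=C3/C(=O)Nc4ccc(Br)cc43)S2)c1` keeps the core of compound 1 and changes in one place: bromo in place of chloro on an aromatic carbon. In short, it has bromo in place of chloro on an aromatic carbon.

Going by the values given here, no two measured compounds differ by a single change, so the data offer no direct guide to a step of this kind. With compound 1 sitting at the limit > 200000 nM in this assay, no step beyond the usual scatter is expected. The expected size of the change is a number no higher from compound 1 to compound 4 (the limit leaves the size open), and the assay may well report only a limit again. For compound 4 the estimated value is 200000 nM, with an expected range from 100000 nM to 400000 nM.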

Compound 4, half-maximal inhibitory concentration: > 200000 nM
Compound 4: no number, only a limit; the forecaster's own chance of this, stated with the estimate: 80%; the middle value lies on the limit itself.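

In this assay compound 4 gives > 200000 nM, which is a limit and not a number. Compound 1 also has only a limit, so no step between the two can be read: the limit of > 200000 nM in this assay, at which 4 of the 4 values shown sit.

Going by these compounds, how bromo and chloro compare at this place stays open, as does any ranking of the four compounds.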